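The source may hold more compounds than are shown below. What is called first, only, known or untested is meant among the compounds shown, and "the series" means these compounds.

Of the compounds shown here, three have so far been measured in an ADME assay on PBMC cells (Homo sapiens) for cytotoxicity; a higher number here means that more compound is tolerated, a lower number that less compound is tolerated. Compound 1 `COC(=O)c1cccc(OC(c2ccc(C(F)(F)F)cc2)C2CCN(C(C)CCNC(=O)c3c(Cl)cncc3Cl)CC2)n1` gives 14600 nM in this assay, the lower of the two plain numbers. Compound 2 `CCO/N=C(/c1ccc(Br)cc1)C1CCN(C(C)(C)CCNC(=O)c2c(Cl)cncc2Cl)CC1` gives 34000 nM in this assay, a gap from compound 1 that lies beyond the usual scatter. Compound 3 `CCO/N=C(/c1ccc(Br)cc1)C1CCN(C(C)CCN(C)C(=O)c2c(C)cc[n+]([O-])c2C)CC1` reaches only a limit of the assay, > 182000 nM, so no number is known for it: the limit of > 182000 nM in this assay, at which 1 of the 3 values shown sits.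

Compound 4 `COC(=O)c1cccc(OC(c2ccc(C(F)(F)F)cc2)C2CCN(C(C)CCNC(=O)c3c(Cl)cncc3Cl)CC2)c1` has not yet been measured. It differs from compound 1 in one place: 3-(methoxycarbonyl)phenyl in place of 6-(methoxycarbonyl)pyridin-2-yl on an oxygen on a saturated carbon. Within the data shown here, no measured pair shows the effect of such a change, so no step beyond the scatter is expected. The step from compound 1 to compound 4 is estimated as a 1.2-fold lower number from compound 1 to compound 4 (0.09 log units; within the scatter). Compound 4 is therefore expected to give about 12000 nM, between 5000 nM and 30000 nM.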

Compound 4, half-maximal cytotoxic concentration: 15200 nM
The estimate for compound 4 lay 1.3-fold (0.10 log units) below the measured number; low and high end bracket the measured number.
By their numbers in this assay, from the lowest: compounds 1 and 4 (each within the scatter of the next); then compound 2. At a limit, above all of these: compound 3.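

Exchanging 6-(methoxycarbonyl)pyridin-2-yl for 3-(methoxycarbonyl)phenyl on this oxygen gives a 1.0-fold higher number from compound 1 to compound 4 (0.02 log units; within the scatter) in this assay, and this pair is the only direct view of this position. At this place, then, a ring carbon can stand in for the ring nitrogen with no readable change in the tolerated concentration. Nothing measured here offers an explanation for this result.

Still open, as far as these compounds go, is whether a carboxylic acid in place of the methoxycarbonyl group, or an amine on the same ring, would move the number beyond the scatter.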